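Sulfonamide arm exchanged for a benzyl(methyl)amino arm

The source may report more compounds than this note shows. Statements on the series, on what has been measured and on what is new or still open speak of the compounds shown alone.

Three compounds share one core and differ only in a side arm on a saturated ring. Compound 1 `c1ccc2c(c1)CCC2NC1CCN(CCCc2c[nH]c3ccc(-n4cnnc4)cc23)CC1`, compound 2 `O=S(=O)(NCC1CCN(CCCc2c[nH]c3ccc(-n4cnnc4)cc23)CC1)c1ccccc1` and compound 3 `COC[C@H](NC1CCN(CCCc2c[nH]c3ccc(Cn4cncn4)cc23)CC1)c1ccc(F)cc1` were tested in a functional assay on CHO cells for activation of 5-hydroxytryptamine receptor 1D (Homo sapiens), read by GTPgammaS binding; a lower number here means a smaller maximal response, a higher number a larger maximal response. Compound 1 gives 68%, compound 2 gives 73% and compound 3 gives 89%. Compound 2 therefore stands second highest of the three, close to compound 1 and clearly below compound 3. Compound 4 `CN(Cc1ccccc1)CC1CCN(CCCc2c[nH]c3ccc(-n4cnnc4)cc23)CC1` differs from compound 2 by benzyl(methyl)amino in place of (phenylsulfonyl)amino on a saturated chain carbon bound to a saturated ring carbon. Within the data shown here, the only single-change step measured so far, a number 5 percentage points higher from compound 1 to compound 2 (within the scatter), concerns the same arm and stayed within the scatter. A similar outcome is expected here: the expected step is a number 2 percentage points lower from compound 2 to compound 4 (within the scatter), within the scatter. Compound 4 is thus estimated at 71%, between 55% and 87%.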

Compound 4, largest response reached (reported as efficacy), in percent of the reference or control that the assay uses: 93%
Beside the measured number, compound 4's estimate is 22 percentage points below it; measured number above the stated range.
By their numbers in this assay, from the lowest: compounds 1 and 2 (each within the scatter of the next); then compounds 3 and 4 (each within the scatter of the next).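

Exchanging (phenylsulfonyl)amino for benzyl(methyl)amino gives a number 20 percentage points higher from compound 2 to compound 4 (beyond the scatter) in this assay, so this arm can shift the maximal response beyond the scatter, which the earlier step between compound 1 and compound 2 did not show. The (benzyl(methyl)amino)methyl arm also gives a number 25 percentage points higher from compound 1 to compound 4 (beyond the scatter) when it takes the place of (2,3-dihydro-1H-inden-1-yl)amino on a saturated ring carbon. No measurement at hand explains this rise. The compounds shown leave open whether the response holds with a plain benzylamino arm, without the methyl, or with phenethyl in place of benzyl.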